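Adding a second methoxy to compound 2

The source may hold more compounds than are shown below. What is called first, only, known or untested is meant among the compounds shown, and "the series" means these compounds.

Compound 1 `Oc1cccc2[nH]c(-c3ccc(-c4ccc(-c5ccc(F)cc5)cc4)cc3)nc12` gives 1220 nM
Compound 2 `COc1ccc(-c2ccc(-c3ccc(-c4nc5c(O)cccc5[nH]4)cc3)cc2)cc1` gives 1630 nM

Both numbers come from a functional assay on COLO 205 cells (Homo sapiens) for inhibition, read by sulforhodamine B assay (a lower number here means a stronger inhibitor of growth, a higher number a weaker inhibitor of growth), and compound 2 at 1630 nM stands within the scatter of compound 1, so the two cannot be ranked. Compound 3 `COc1ccc(-c2ccc(-c3ccc(-c4nc5c(O)cccc5[nH]4)cc3)cc2)cc1OC` differs from compound 2 in one place methoxy in place of hydrogen on an aromatic carbon where methoxy stands in place of hydrogen on an aromatic carbon, so 4-methoxyphenyl becomes 3,4-dimethoxyphenyl. Going by the values given here, the only measured step on this part of the structure is a 1.3-fold higher number from compound 1 to compound 2 (0.13 log units; within the scatter) and it exchanges fluoro for methoxy rather than adding a group, so it bears on the new change only loosely. That step was small and no added methoxy has been measured, so no shift beyond the scatter is expected in this assay for this change. The expected step is a 1.1-fold higher number from compound 2 to compound 3 (0.04 log units; within the scatter) and it is estimated to remain small. For compound 3 the estimated value is 1800 nM with an expected range of 700 nM to 4500 nM in this estimate.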

Compound 3, concentration for 50% growth inhibition: 1320 nM
The estimate for compound 3 lay 1.4-fold (0.13 log units) above the measured number; measured number inside the range.
By their numbers in this assay, from the lowest: compounds 1, 3 and 2 (each within the scatter of the next).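

In this assay, a methoxy placed on the six-membered aromatic ring, ortho to the existing methoxy group, gives a 1.2-fold lower number from compound 2 to compound 3 (0.09 log units; within the scatter), so a second methoxy at this position produces no shift that can be told from the scatter. The wider exchange of 4-fluorophenyl for 3,4-dimethoxyphenyl gives a 1.1-fold higher number from compound 1 to compound 3 (0.03 log units; within the scatter), so compound 3 cannot be ranked against compound 1 either, and the three compounds form one flat set in this assay. Nothing shown here offers an explanation for this flat result.

What the compounds leave open is whether any group at this position can move growth inhibition beyond the scatter. An amine, a carboxylic acid or a longer chain such as butoxy might do so, and the methoxy and fluoro compounds cannot settle that.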